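A methyl group moves, and the limit stays in view

A few compounds are considered here, and "the series" means these few. Any claim that something is new, unique, unknown or untested is made for them only; others in the source may bear on it.

Three amides sharing one core have been measured in a toxicity assay on THP-1 cells (Homo sapiens) for inhibition; a higher number here means that more compound is tolerated, a lower number that less compound is tolerated. Compound 1 (`COc1ccc(-c2cnc(NC(=O)c3cnc[nH]3)n2C)cc1`) gives > 100000 nM as a limit of the assay and not a number. Compound 2 (`COc1ccc(-c2cnc(NC(=O)c3ccno3)n2C)cc1`) gives > 100000 nM as a limit too. Compound 3 (`COc1ccc(-c2cnc(NC(=O)c3ccc(C)cc3)n2C)cc1`) also gives only a limit with > 100000 nM and no exact figure. Together they show the limit of > 100000 nM in this assay, at which 3 of the 3 values shown sit, and no number to compare.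

Compound 4 (`COc1ccc(-c2cnc(NC(=O)c3cccc(C)c3)n2C)cc1`) carries 3-methylphenyl in place of 4-methylphenyl on a carbonyl carbon and has the same atoms as compound 3, joined differently. Among the compounds with values here, the steps that bear on this change sit at that same carbon: a step that the two limits leave unreadable from compound 1 to compound 3 and a step that the two limits leave unreadable from compound 2 to compound 3 as well as a step that the two limits leave unreadable from compound 1 to compound 2 in the same place. None has a readable size, yet none of them left the limit.

The expected result is a number no higher from compound 3 to compound 4 (the limit leaves the size open) with no direction beyond the scatter. Compound 4 is estimated at 100000 nM within an expected range from 50000 nM to 200000 nM and will probably be reported only as a limit.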

Compound 4, half-maximal cytotoxic concentration: > 100000 nM
Compound 4 ended at the assay's limit (the forecaster's own chance of this, stated with the estimate: 90%); the middle value sits exactly at the limit.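

Within the data shown here, compound 4 gives only a limit of the assay and not a number, just as compound 1, compound 2 and compound 3 do, so no step among them can be read: the limit of > 100000 nM in this assay, at which 4 of the 4 values shown sit.

As far as these compounds go, how much of any of these four compounds is tolerated beyond that limit, and whether moving the methyl group changes it, stays open.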